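Acetyl in place of dimethylamino: an expected shift in cytotoxicity

This account rests on a few compounds, and the source may have more. Where it says the series, first, only, none or still open, it means among the compounds named here.

Of the compounds shown here, two have been measured in a functional assay on NCI-H23 cells (Homo sapiens) for cytotoxicity, read by sulforhodamine B assay, with a stated time of 48 h, tested at 0.01 uM; on this read-out lower numbers stand for a stronger effect and higher numbers for a weaker effect at the one concentration tested. Compound 1 `COc1cc(C)cc(-c2c(-c3ccnc(-c4ccc(N(C)C)cc4)c3)cnn2CC#N)c1` gives 67% in this assay, the lowest of the two numbers. Compound 2 `COc1cc(C)cc(-c2nn(CC#N)cc2-c2ccc(-c3cccc(C(C)=O)c3)nc2)c1` gives 91% in this assay, a gap from compound 1 that lies beyond the usual scatter; since these two structures differ in more than one place, their values show only that much.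

Compound 3 `COc1cc(C)cc(-c2c(-c3ccnc(-c4ccc(C(C)=O)cc4)c3)cnn2CC#N)c1` has not yet been measured. It differs from compound 1 in a single place: acetyl in place of dimethylamino on an aromatic carbon. Among the measured compounds shown here, no measured pair shows this exact change, so the expectation rests on the thin evidence that compound 2, the only measured compound bearing an acetyl on a phenyl ring, sits at 91%. The step is therefore expected to go toward weaker effect, likely just beyond the scatter, by a number 13 percentage points higher from compound 1 to compound 3 (beyond the scatter). Compound 3 is estimated to give 80%, with a range from 62% to 98%.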

Compound 3, a percentage reported as activity, at one concentration (the size of the read-out at that concentration, not a potency): 95%
Compound 3: middle estimate off by 15 percentage points, on the low side; the range from low to high includes it.
By their numbers in this assay, from the lowest: compound 1; then compounds 2 and 3 (each within the scatter of the next).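

In this assay, among the compounds shown here, exchanging dimethylamino for acetyl on the aromatic carbon para to a large group gives a number 28 percentage points higher from compound 1 to compound 3 (beyond the scatter), the first step that can be read at a single place. With the rest of the structure unchanged, the group at this position alone separates the two compounds, even though dimethylamino and acetyl match in heavy atoms and in hydrogen-bond donors and acceptors as counted. Nothing available explains the step.

The compounds shown leave open whether a primary amine, a methoxy group or a carboxylic acid at this position would read closer to compound 1 or to compound 3. They also leave open whether the step holds at other concentrations, since the read-out comes from a single concentration.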